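Cyano in place of acetyl: notes toward compound 4

The source may report more compounds than this note shows. Statements on the series, on what has been measured and on what is new or still open speak of the compounds shown alone.

- compound 1 `Cc1cc(/C=C/C#N)cc(C)c1Oc1cc(Nc2ccc(C#N)cc2)c([N+](=O)[O-])cc1[N+](=O)[O-]` (21700 nM)
- compound 2 `Cc1cc(/C=C/C#N)cc(C)c1Oc1ccc(N)c(Nc2ccc(C#N)cc2)c1` (8830 nM)
- compound 3 `CC(=O)/C=C/c1cc(C)c(Oc2cc(Nc3ccc(C#N)cc3)c(N)cc2[N+](=O)[O-])c(C)c1` (22600 nM)

All three numbers come from an ADME assay on MT2 cells (Homo sapiens) for cytotoxicity, read by XTT assay, with a stated time of 4 days (on this read-out lower numbers stand for higher toxicity in this test and higher numbers for lower toxicity in this test), and the next entry, compound 4 `Cc1cc(/C=C/C#N)cc(C)c1Oc1cc(Nc2ccc(C#N)cc2)c(N)cc1[N+](=O)[O-]`, has no number yet. Compound 3 (22600 nM) and compound 1 (21700 nM) lie within the scatter of each other, while compound 2 (8830 nM) lies lower than compound 3, beyond the scatter.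

Going on to compound 4, the change reads cyano in place of acetyl on a double-bonded chain carbon bound to a double-bonded chain carbon and amounts to cyano in place of acetyl on a double-bonded chain carbon bound to a double-bonded chain carbon, or 2-acetylethenyl to 2-cyanoethenyl. Within the data shown here, no measured pair isolates this change, so any expectation remains loose. The 2-cyanoethenyl group already stands in compound 2 (8830 nM) and in compound 1 (21700 nM), and a number between these two would fit. In this assay no step beyond the scatter is expected, with a slight lean toward a lower number. The expected change is a 1.4-fold lower number from compound 3 to compound 4 (0.15 log units; within the scatter) and would stay within the scatter. For compound 4 the estimated value is 16000 nM, with an expected range from 7000 nM to 35000 nM.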

Compound 4, half-maximal cytotoxic concentration: 88200 nM
Estimate against measurement, compound 4: 5.5-fold (0.74 log units) below; the whole stated range lies below it.
By their numbers in this assay, from the lowest: compound 2; then compounds 1 and 3 (each within the scatter of the next); then compound 4.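

In this assay, among these compounds, the move from 2-acetylethenyl to 2-cyanoethenyl gives a 3.9-fold higher number from compound 3 to compound 4 (0.59 log units; beyond the scatter) on the shared core, so this chain position, which no earlier pair isolated, does shift the read-out, here toward lower toxicity in this test. The two aromatic changes also end at compound 4 and lie beyond the scatter: nitro in place of hydrogen on an aromatic carbon gives a 10-fold higher number from compound 2 to compound 4 (1.00 log units; beyond the scatter) and amino in place of nitro on an aromatic carbon gives a 4.1-fold higher number from compound 1 to compound 4 (0.61 log units; beyond the scatter) as the second single-place change, which leaves compound 4 with the highest number of the four and with each of its steps to the others beyond the scatter. No evidence is available on why these numbers rise.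

From the compounds shown here alone, the cyano-for-acetyl step rests on one pair with one set of aromatic groups, so whether it carries over to the cores of compound 1 and compound 2 stays open. Also open, going by these compounds, is how a carboxylic acid, a primary amide or a longer chain would read at this position on the double-bonded chain carbon.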